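Replacing a Fluorophenyl Group with a Short Propyl Chain

The source may hold more compounds than are shown below. What is called first, only, known or untested is meant among the compounds shown, and "the series" means these compounds.

Of the compounds shown here, two sharing one core have been measured in an in vitro functional assay on cells for agonist activity at Bombesin receptor subtype-3 (Mus musculus), read by luminescence and calcium flux; a higher number here means that more compound is needed for the effect, a lower number that less compound is needed. Compound 1 `O=C(O)c1ccccc1-c1ccc(CCc2ncc(Cc3ccccc3Cl)[nH]2)cc1` gives 22 nM in this assay, and compound 2 `O=C(O)c1ccccc1-c1ccc(CCc2ncc(Cc3cccc(F)c3)[nH]2)cc1` gives 7.9 nM. Within the data shown here, the single step between them, a 2.8-fold lower number from compound 1 to compound 2 (0.44 log units; beyond the scatter), is the whole of what is known about substitution at this site. Compound 2 therefore stands at the lower of the two numbers, with compound 1 above it by that step.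

Compound 3 `CCCCc1cnc(CCc2ccc(-c3ccccc3C(=O)O)cc2)[nH]1` has not yet been measured. Its difference from compound 2 is propyl in place of 3-fluorophenyl on a saturated chain carbon bound to an aromatic carbon. Among the measured compounds shown here, no measured step exchanges an aromatic ring for an open chain at this position; the step from compound 1 to compound 2 only swaps one substituted phenyl for another, and its modest size does not settle how a propyl chain will fare. For the measured compounds named here, the exchange thus has no direct precedent, and the expectation rests only on the fact that both measured compounds keep an aromatic ring here. The step is estimated as a 5.1-fold higher number from compound 2 to compound 3 (0.70 log units; beyond the scatter), a rise in the number being expected. Compound 3 is estimated at 40 nM, with an expected range from 8 nM to 200 nM.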

Compound 3, half-maximal effective concentration: 93 nM
Estimate against measurement, compound 3: 2.3-fold (0.37 log units) below; the measured number falls inside the stated range.
By their numbers in this assay, from the lowest: compound 2; then compound 1; then compound 3.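

The exchange of an aromatic ring for an open chain on a saturated chain carbon bound to an aromatic carbon now has a measured size. In this assay, propyl in place of 3-fluorophenyl gives a 12-fold higher number from compound 2 to compound 3 (1.07 log units; beyond the scatter), while propyl in place of 2-chlorophenyl gives a 4.2-fold higher number from compound 1 to compound 3 (0.63 log units; beyond the scatter), so both compounds that keep a phenyl ring here have lower numbers than the propyl compound, and the size of the rise depends on which substituted phenyl leaves. The aromatic ring is nevertheless not required for a response, since compound 3 still gives 93 nM, and nothing at hand offers an explanation for the size of these steps.

The change removes the aromatic ring and shortens the substituent from 7 heavy atoms to 3 at once, so the compounds shown cannot tell which of the two accounts for the rise. A cyclohexyl ring at this position would separate the two, and a longer chain such as hexyl would show whether open chains as a class give higher numbers here or whether propyl alone does.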